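This account rests on a few compounds, and the source may have more. Where it says the series, first, only, none or still open, it means among the compounds named here.

Measured in an ADME assay on Vero cells (Chlorocebus sabaeus) for cytotoxicity, read by resazurin assay, with a stated time of 3 days; on this read-out lower numbers stand for stronger inhibition and higher numbers for weaker inhibition:
compound 1 `CCN(CC)c1cc2[nH]c(C3CCCCC3)nc2cc1NC(=O)c1ccc(N(C)C)cc1`: "not determined" (no result reported)
compound 2 `CCCCOC(=O)Nc1cc2nc(C3CCCCC3)[nH]c2cc1N(C)C`: > 100 ug/mL
compound 3 `CCCCOC(=O)Nc1cc2nc(C3CCCCC3)[nH]c2cc1N(CC)CC`: > 100 ug/mL

In this assay compound 3 stands at > 100 ug/mL, which is a limit and not a number. Compound 4 `CCCCOC(=O)Nc1cc2nc(C3CCCCC3)[nH]c2cc1N(C)CCN(C)C` has (2-(dimethylamino)ethyl)(methyl)amino in place of diethylamino on an aromatic carbon, ortho to a (butoxycarbonyl)amino group: (2-(dimethylamino)ethyl)(methyl)amino in place of diethylamino on an aromatic carbon. Among the measured compounds shown here, the one measured step at this place is a step that the two limits leave unreadable from compound 2 to compound 3, so no size can be carried over. What remains is the limit of > 100 ug/mL in this assay, at which 2 of the 3 values shown sit. A value near that limit is therefore expected in this assay, with some room towards stronger inhibition. The estimated change is an at least 1.2-fold lower number from compound 3 to compound 4 (0.09 log units; that floor lies within the scatter). For compound 4 the expected value is 80 ug/mL, with an estimated range of 25 ug/mL to 120 ug/mL.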

Compound 4, half-maximal inhibitory concentration: > 100 ug/mL
Compound 4 was reported as a limit; the forecaster's own chance of this, stated with the estimate: 50%; middle value at least 1.2-fold (0.09 log units) from the limit.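

In this assay compound 4 gives > 100 ug/mL, a limit and not a number. Compound 2 and compound 3 are also reported as limits, so the steps among these three compounds cannot be read. As far as these compounds go, whether these amino groups differ at all in this assay stays open.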